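The source may hold more compounds than are shown below. What is called first, only, known or untested is meant among the compounds shown, and "the series" means these compounds.

Measured so far in an assay on isolated protein for inhibition of polyamine deacetylase HDAC10 (Homo sapiens); a lower number here means a stronger inhibitor, a higher number a weaker inhibitor:

- compound 1, `COc1ccc(C(=O)c2ccc3c(ccn3Cc3ccc(C(=O)NO)cc3)c2)cc1OC`: 18900 nM
- compound 2, `O=C(NO)c1ccc(Cn2ccc3cc(C(=O)c4ccc(F)cc4)ccc32)cc1`: > 100000 nM
- compound 3, `COc1ccc(C(=O)c2ccc3c(ccn3S(=O)(=O)c3cccc(/C=C/C(=O)NO)c3)c2)cc1OC`: 8240 nM.

For compound 2 the value in this assay is a limit of the assay and not a number. The change from compound 1 to compound 2 is 4-fluorophenyl in place of 3,4-dimethoxyphenyl on a carbonyl carbon; the step it made is an at least 5.2-fold higher number from compound 1 to compound 2 (0.72 log units; beyond the scatter), and its size can only be given as a lower bound because of the limit of > 100000 nM in this assay, at which 1 of the 3 values shown sits.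

Compound 3 has the lowest number of the two numbers shown. The difference between the core of compound 1 and the core of compound 3 is not broken down here.

Compound 4, `O=C(/C=C/c1cccc(S(=O)(=O)n2ccc3cc(C(=O)c4ccc(F)cc4)ccc32)c1)NO`, is not yet measured. It stands to compound 3 as compound 2 stands to compound 1: the change is 4-fluorophenyl in place of 3,4-dimethoxyphenyl on a carbonyl carbon, and the place is the same as in the earlier pair, so this is the same change.

For compound 4 in this assay a step of a 6.1-fold higher number from compound 3 to compound 4 (0.78 log units; beyond the scatter) is expected, beside the earlier one, resting on the step from compound 1 to compound 2 an at least 5.2-fold higher number from compound 1 to compound 2 (0.72 log units; beyond the scatter); since that step is only a lower bound, the expected step is uncertain in size. Compound 4 is estimated at 50000 nM, between 20000 nM and 150000 nM, with a fair chance that only a limit is reported.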

Compound 4, half-maximal inhibitory concentration: 5240 nM
Estimate against measurement, compound 4: 9.5-fold (0.98 log units) above; the measured number lies below the stated range.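

In this assay, 4-fluorophenyl in place of 3,4-dimethoxyphenyl on a carbonyl carbon gives a 1.6-fold lower number from compound 3 to compound 4 (0.20 log units; within the scatter), so the step seen on the core of compound 1 does not carry over to the core of compound 3: the same change on two cores in this assay, an at least 5.2-fold higher number (0.72 log units; beyond the scatter) from compound 1 to compound 2 and a 1.6-fold lower number (0.20 log units; within the scatter) from compound 3 to compound 4, at least 8.3-fold (0.92 log units) apart, beyond the scatter of two such steps

The earlier step can be sized only as a lower bound, since the value of compound 2 is a limit of the assay and not a number: the limit of > 100000 nM in this assay, at which 1 of the 4 values shown sits.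

The cores of compound 1 and compound 3 differ in more than one place, and a single pair on each core does not show which part of the core goes with the different outcome, or how the change would behave on any further core.

Still open, on these data alone, is whether the outcome on the core of compound 3 holds for other groups on the carbonyl carbon, such as an unsubstituted phenyl or an amine. Also open, as far as these compounds go, is how a core combining parts of the cores of compound 1 and compound 3 would respond to the same change.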